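Amine substituent and binding in a weakly active triazolopyrimidine series

A few compounds are considered here, and "the series" means these few. Any claim that something is new, unique, unknown or untested is made for them only; others in the source may bear on it.

Measured compounds:
- compound 1, `CCNc1nc(-c2ccccc2)nc2c1nnn2Cc1ccccc1F`: 11000000 nM
- compound 2, `CC(O)CNc1nc(-c2ccccc2)nc2c1nnn2Cc1ccccc1F`: 4800000 nM
- compound 3, `CNc1nc(-c2ccccc2)nc2c1nnn2Cc1ccccc1F`: 25000000 nM

All three share one core and differ only in the group carried on the nitrogen attached to the aromatic ring. In an assay on isolated protein for binding affinity to adenosine receptor A1 (Bos taurus) (a lower number here means a stronger inhibitor, a higher number a weaker inhibitor), compound 3 gives 25000000 nM, the highest number of the three, so it is the weakest binder among them. The nearest is compound 1 with 11000000 nM; the step is a 2.3-fold higher number from compound 1 to compound 3 (0.36 log units; beyond the scatter). The furthest is compound 2, where a 5.2-fold higher number from compound 2 to compound 3 (0.72 log units; beyond the scatter) shows that removing the 1-hydroxyethyl group raised the number most.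

Compound 4, `OC1CCC(Nc2nc(-c3ccccc3)nc3c2nnn3Cc2ccccc2F)CC1`, takes the amine substituent further in the same direction: 4-hydroxycyclohexyl in place of methyl on a nitrogen on an aromatic ring. Both measured steps that touch compound 3 point the same way: a group carrying more atoms on that nitrogen gives a lower number, and the step from compound 2 to compound 3, where a hydroxyl-bearing group was present, was the larger of the two. Since compound 4 also brings a hydroxyl group on a ring, the number is expected to fall by at least as much as it rose in a 5.2-fold higher number from compound 2 to compound 3 (0.72 log units; beyond the scatter), and possibly somewhat more.

Compound 4 is therefore estimated at 2000000 nM, with a plausible range of 400000 nM to 10000000 nM, meaning an expected step of a 13-fold lower number from compound 3 to compound 4 (1.10 log units; beyond the scatter).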

Compound 4, inhibition constant: 1850000 nM
The estimate for compound 4 lay 1.1-fold (0.03 log units) above the measured number; low and high end bracket the measured number.
By their numbers in this assay, from the lowest: compound 4; then compound 2; then compound 1; then compound 3.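

In this assay, among these compounds, 4-hydroxycyclohexyl on the nitrogen gives the biggest shift yet seen at this position, with a 14-fold lower number from compound 3 to compound 4 (1.13 log units; beyond the scatter) the only step rated large. The gain is not limited to the smallest group, since the same ring also gives a 5.9-fold lower number from compound 1 to compound 4 (0.77 log units; beyond the scatter) and, against a chain that likewise carries a hydroxyl group, a 2.6-fold lower number from compound 2 to compound 4 (0.41 log units; beyond the scatter), which shows that having a hydroxyl group is not all that matters here. Across these four compounds the number falls in the order methyl, ethyl, 2-hydroxypropyl, 4-hydroxycyclohexyl, with none going against that order, so the position still responds to a larger group and compound 4 is the strongest binder of the set.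

The ring and the hydroxyl group enter together in compound 4, so their shares cannot be separated without a plain cyclohexyl group on the same nitrogen, and a longer chain such as butyl would test whether a ring is needed at all. Nothing measured here gives a reason for the trend.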